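Furan ethers: triazole to imidazole swap and macrophage cytotoxicity

The source may report more compounds than this note shows. Statements on the series, on what has been measured and on what is new or still open speak of the compounds shown alone.

Measured compounds:
compound 1 `Clc1cccc(COC(CCn2cncn2)c2ccco2)c1`: 18600 nM
compound 2 `Clc1cccc(COC(CCn2ccnc2)c2ccco2)c1`: 60200 nM
compound 3 `Fc1ccc(F)c(COC(CCn2cncn2)c2ccco2)c1`: "not determined" (no result reported)

In an ADME assay on J774.A1 cells (Mus musculus) for cytotoxicity, read by MTT assay, with a stated time of 72 h (on this read-out higher numbers stand for lower toxicity in this test and lower numbers for higher toxicity in this test), compound 1 gives 18600 nM and compound 2 gives 60200 nM. The difference between them is 1H-imidazol-1-yl in place of 1H-1,2,4-triazol-1-yl on a saturated chain carbon, three bonds along the chain from an aromatic carbon and an oxygen on a saturated carbon; it made a step of a 3.2-fold higher number from compound 1 to compound 2 (0.51 log units; beyond the scatter). Compound 3 carries a different core; how its core differs from that of compound 1 is not broken down here, and compound 3 has no number in this assay.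

Compound 4 `Fc1ccc(F)c(COC(CCn2ccnc2)c2ccco2)c1` differs from compound 3 by 1H-imidazol-1-yl in place of 1H-1,2,4-triazol-1-yl on a saturated chain carbon, three bonds along the chain from an aromatic carbon and an oxygen on a saturated carbon, the same change at the same place as between compound 1 and compound 2. For the measured compounds named here, with no value for compound 3, the size of that step cannot be applied here; the expectation for compound 4 rests instead on compound 2, whose 60200 nM is the only number for an imidazolyl member of the series. Compound 4 is therefore estimated at 50000 nM, expected to lie between 12000 nM and 200000 nM.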

Compound 4, half-maximal cytotoxic concentration: 30900 nM
Beside the measured number, compound 4's estimate is 1.6-fold (0.21 log units) above it, within the range that was stated.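

For the compounds shown here, compound 3 holds no number in this assay, so no step to compound 4 can be read. On these data alone, whether 1H-imidazol-1-yl in place of 1H-1,2,4-triazol-1-yl acts on this core as it does on the core of compound 1 stays open. Nothing available explains these values.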